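A few compounds are considered here, and "the series" means these few. Any claim that something is new, unique, unknown or untested is made for them only; others in the source may bear on it.

Measured so far:
compound 1 `O=C(Nc1ccccc1O)C1CCc2ccccc2N1C(=O)c1ccc(Cl)cc1` — 13400 nM
compound 2 `O=C(Nc1ccccc1C(F)(F)F)C1CCc2ccccc2N1C(=O)c1ccc(Cl)cc1` — 551 nM

For the measured compounds named here, in a functional assay on NUGC-3 cells (Homo sapiens) for cytotoxicity, read by sulforhodamine B assay, with a stated time of 72 h (on this read-out lower numbers stand for stronger inhibition of growth and higher numbers for weaker inhibition of growth), compound 1 gives 13400 nM, the higher of the two numbers known; compound 2 gives 551 nM. Going by the values given here, the single measured step, a 24-fold lower number from compound 1 to compound 2 (1.39 log units; beyond the scatter), changes the group on the anilide ring and leaves the (4-chlorophenyl)carbonyl untouched, so it says nothing direct about moving the chlorine on that ring.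

Compound 3 `O=C(Nc1ccccc1O)C1CCc2ccccc2N1C(=O)c1cccc(Cl)c1` differs from compound 1 only in that respect: 3-chlorophenyl in place of 4-chlorophenyl on a carbonyl carbon. Among the compounds with values here, no measured pair in this assay bears on such a change; the series so far holds no other chlorophenyl isomer. With nothing to point either way, the working expectation for compound 3 is a step of no more than the usual scatter from compound 1, a 1.0-fold lower number from compound 1 to compound 3 (0.01 log units; within the scatter). Compound 3 is therefore estimated at 13000 nM in this assay, with a wide range of 4000 nM to 40000 nM to reflect the absence of any informing step.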

Compound 3, concentration for 50% growth inhibition: 11000 nM
Compound 3: the middle estimate sits 1.2-fold (0.07 log units) above what was measured, within the range that was stated.
By their numbers in this assay, from the lowest: compound 2; then compounds 3 and 1 (each within the scatter of the next).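

In this assay, the chlorine position on the (4-chlorophenyl)carbonyl can now be read directly: with hydroxy held on the other aromatic ring, 3-chlorophenyl in place of 4-chlorophenyl gives a 1.2-fold lower number from compound 1 to compound 3 (0.09 log units; within the scatter). For the compounds shown here, in this pair, the two chlorophenyl isomers cannot be told apart, whereas the one earlier step, a 24-fold lower number from compound 1 to compound 2 (1.39 log units; beyond the scatter), changed hydroxy to trifluoromethyl and left the chlorophenyl untouched. No separate measurement is available to interpret this result.

Going by these compounds, it remains open whether the two isomers also read alike when trifluoromethyl replaces hydroxy, as in compound 2. Also open, on these data alone, is what the chlorine itself contributes, which an unsubstituted phenyl or a methoxy or amine in place of the chlorine on the same carbonyl-bound phenyl could test.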